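Chloro to methyl on the carbonyl-bearing phenyl ring

The source may hold more compounds than are shown below. What is called first, only, known or untested is meant among the compounds shown, and "the series" means these compounds.

Measured so far:
Compound 1 `Cc1ccc(-c2nn(-c3ccccc3)cc2-c2nc3ccccc3n2C(=O)c2ccccc2)cc1` gives 204000 nM in an ADME assay on HEK-293T cells (Homo sapiens) for cytotoxicity, read by MTT assay, with a stated time of 24 h; a higher number here means that more compound is tolerated, a lower number that less compound is tolerated.
Compound 2 `Cc1ccc(-c2nn(-c3ccccc3)cc2-c2nc3ccccc3n2C(=O)c2ccc(Cl)cc2)cc1` gives 216000 nM in this assay.

Of the two numbers, compound 2 carries the larger, but compound 1 lies within the usual scatter of it, so the two are not distinguished. Among the compounds with values here, the one step that bears on the next change is a 1.1-fold higher number from compound 1 to compound 2 (0.02 log units; within the scatter), also a swap on an aromatic carbon. Compound 3 `Cc1ccc(C(=O)n2c(-c3cn(-c4ccccc4)nc3-c3ccc(C)cc3)nc3ccccc32)cc1` differs from compound 2 by methyl in place of chloro on an aromatic carbon. Within the data shown here, since the sole relevant step stayed within the scatter, no shift beyond the scatter is expected for compound 3 in this assay, the expected step being a 1.0-fold lower number from compound 2 to compound 3 (0.01 log units; within the scatter). Compound 3 is estimated at 210000 nM, with a range from 105000 nM to 420000 nM.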

Compound 3, half-maximal cytotoxic concentration: 176000 nM
Estimate against measurement, compound 3: 1.2-fold (0.08 log units) above; measured number inside the range.
By their numbers in this assay, from the lowest: compounds 3, 1 and 2 (each within the scatter of the next).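

In this assay, methyl in place of chloro gives (a 1.2-fold lower number from compound 2 to compound 3 (0.09 log units; within the scatter)), and methyl in place of hydrogen gives (a 1.2-fold lower number from compound 1 to compound 3 (0.06 log units; within the scatter)). Hydrogen, chloro and methyl are therefore not distinguished at this place, para to a large group, where the earlier pair covered only hydrogen and chloro. No evidence on hand bears on this result.

As far as these compounds go, whether an amine, a carboxylic acid or a longer chain at this place would stay within the scatter remains open. So does whether methyl or chloro on the other rings of the core would do the same.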